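Ester Side Chain Changes and Plasma Stability

The source may hold more compounds than are shown below. What is called first, only, known or untested is meant among the compounds shown, and "the series" means these compounds.

Three compounds have been measured in an ADME assay on a cell-free system (plasma, Homo sapiens) for metabolic stability, read by LC-MS; on this read-out higher numbers stand for a longer-lived compound and lower numbers for a shorter-lived compound:
compound 1 `CCCCCOC(=O)c1cccc(-c2cc(C(=O)Nc3ccncc3)ccc2CN)c1`: 0.967 h
compound 2 `CCCCCCOC(=O)c1cccc(-c2cc(C(=O)Nc3ccncc3)ccc2CN)c1`: 0.833 h
compound 3 `CC(C)OCCOC(=O)c1cccc(-c2cc(C(=O)Nc3ccncc3F)ccc2CN)c1`: 0.1 h

Compound 3 stands lowest of the three in this assay. Its nearest neighbour is compound 2, whose value of 0.833 h lies beyond the scatter above it, and compound 1 with 0.967 h lies further still. Within the data shown here, compound 3 differs from compound 1 and from compound 2 in more than one place, so no single step links them; the values simply show the gap.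

Compound 4 `NCc1ccc(C(=O)Nc2ccncc2F)cc1-c1cccc(C(=O)OCC2CCCCO2)c1` has not yet been measured. It differs from compound 3 in one place: oxan-2-yl in place of isopropoxymethyl on a saturated chain carbon bound to an oxygen next to a carbonyl group. Among the measured compounds shown here, the only measured step, a 1.2-fold lower number from compound 1 to compound 2 (0.06 log units; within the scatter), also altered the chain bound to the oxygen next to the carbonyl group and stayed within the scatter; it lengthened a chain rather than closing a ring, so it bears only loosely on the present change. On that precedent the step is expected to be small: a 1.8-fold higher number from compound 3 to compound 4 (0.26 log units; within the scatter). The estimated half-life of compound 4 in this assay is therefore 0.18 h, with a range from 0.06 h to 0.55 h.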

Compound 4, half-life: 0.117 h
The estimate for compound 4 lay 1.5-fold (0.19 log units) above the measured number; the measured number falls inside the stated range.
By their numbers in this assay, from the lowest: compounds 3 and 4 (each within the scatter of the next); then compounds 2 and 1 (each within the scatter of the next).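

In this assay, putting oxan-2-yl in place of isopropoxymethyl on a saturated chain carbon bound to an oxygen next to a carbonyl group gives a 1.2-fold higher number from compound 3 to compound 4 (0.07 log units; within the scatter) and so leaves the half-life unchanged within the scatter. The earlier step at this end of the molecule only lengthened an open chain, whereas this one replaces an open chain with a six-membered non-aromatic ring, and on the core of compound 3 that exchange of side chain does not lift the number out of the scatter. Nothing shown here gives a reason for this result.

Compounds 1 and 2 differ from compounds 3 and 4 in more than one place, so the compounds shown cannot say which difference accounts for the higher numbers of compounds 1 and 2. As far as these compounds go, it also stays open whether the same carbon would tolerate a quite different group, such as an amine, a carboxylic acid or a longer chain, with as small a step, and whether oxan-2-yl would behave the same way on the core of compound 1.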